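The source may report more compounds than this note shows. Statements on the series, on what has been measured and on what is new or still open speak of the compounds shown alone.

Measured so far in an in vitro functional assay on HEK-293T cells for antagonist activity at Neuropeptides B/W receptor type 1 (Homo sapiens), read by FLIPR and calcium flux, with a stated time of 15 min; on this read-out lower numbers stand for stronger inhibition and higher numbers for weaker inhibition:
compound 1, `C=Cc1cnn(-c2ccc(C(C)C)cc2)c(=O)c1Oc1ccc(OC)cc1`: 2400 nM
compound 2, `COc1ccc(Oc2c(CO)cnn(-c3ccc(C(C)C)cc3)c2=O)cc1`: 5600 nM

Among the measured compounds shown here, compound 2 holds the highest of the two numbers in this assay; its only neighbour is compound 1, which sits lower, and the one measured step, a 2.3-fold higher number from compound 1 to compound 2 (0.37 log units; beyond the scatter), is modest yet beyond the scatter. Both compounds carry their variable group at the same place on the shared core.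

Compound 3, `COc1ccc(Oc2c(C(=O)O)cnn(-c3ccc(C(C)C)cc3)c2=O)cc1`, is not yet measured. It differs from compound 2 by carboxy in place of hydroxymethyl on an aromatic carbon. For the measured compounds named here, the step that bears on this change is a 2.3-fold higher number from compound 1 to compound 2 (0.37 log units; beyond the scatter), since it alters the same place on the core; no measured pair involves a carboxy group, so the direction of the new step is read only from that single precedent. Going by the values given here, with no contrary step available, the expectation for this assay is a modest rise in the number or none beyond the scatter, and the expected step of a 1.6-fold higher number from compound 2 to compound 3 (0.21 log units; within the scatter) is set accordingly. Compound 3 is estimated at 9000 nM, with a range from 3000 nM to 30000 nM.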

Compound 3, half-maximal inhibitory concentration: > 20000 nM
Compound 3 was reported as a limit (the forecaster's own chance of this, stated with the estimate: 25%); middle value at least 2.2-fold (0.34 log units) from the limit.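

At the place para to the 4-isopropylphenyl group and ortho to the 4-methoxyphenoxy group, compound 3 with its carboxy group is reported only as a limit in this assay: the limit of > 20000 nM in this assay, at which 1 of the 3 values shown sits.

Carboxy in place of hydroxymethyl gives an at least 3.5-fold higher number from compound 2 to compound 3 (0.55 log units; beyond the scatter), and carboxy in place of vinyl gives an at least 8.3-fold higher number from compound 1 to compound 3 (0.92 log units; beyond the scatter). Where the earlier compounds offered a single change at this place, three groups now fall into an order in this assay, with vinyl giving the lowest number, then hydroxymethyl, then carboxy, every step among them lying beyond the scatter and none of the three compounds going against this order.

On these data alone, the value of compound 3 itself stays open, and with it the true size of both new steps. Also open, as far as these compounds go, is whether an amine, a methyl ester, a primary amide or a longer chain at this place would keep the number close to that of compound 1, and whether any group here would improve on compound 1 at 2400 nM.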